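The source may hold more compounds than are shown below. What is called first, only, known or untested is meant among the compounds shown, and "the series" means these compounds.

Among the measured compounds shown here, compound 2 `Cc1ccc(-n2cc(COc3cccc(NC(=O)Nc4ccc(Cl)c(C(F)(F)F)c4)c3)nn2)cc1` gives 5430 nM in a functional assay on HepG2 cells (Homo sapiens) for inhibition, read by MTT assay, with a stated time of 72 h (on this read-out higher numbers stand for weaker inhibition and lower numbers for stronger inhibition), the highest of the two numbers so far; the nearest is compound 1 `COc1ccc(-n2cc(COc3cccc(NC(=O)Nc4ccc(Cl)c(C(F)(F)F)c4)c3)nn2)cc1`, which gives 4680 nM. For the measured compounds named here, the one step available, a 1.2-fold higher number from compound 1 to compound 2 (0.06 log units; within the scatter), lies within the scatter. Compound 3 `CCc1ccccc1-n1cc(COc2cccc(NC(=O)Nc3ccc(Cl)c(C(F)(F)F)c3)c2)nn1` differs from compound 2 by 2-ethylphenyl in place of 4-methylphenyl on an aromatic nitrogen. Going by the values given here, only that step bears on this change, and it shows no effect beyond the scatter for a substituent swap on this aryl group, so no step beyond the scatter is expected, a 1.0-fold higher number from compound 2 to compound 3 (0.01 log units; within the scatter). Compound 3 is therefore estimated at 5500 nM, with a range of 2500 nM to 12000 nM.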

Compound 3, half-maximal inhibitory concentration: 3530 nM
For compound 3 the middle estimate is 1.6-fold (0.19 log units) above the measured one; measured number inside the range.
By their numbers in this assay, from the lowest: compounds 3, 1 and 2 (each within the scatter of the next).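

With 2-ethylphenyl on the aromatic nitrogen, this assay gives a 1.5-fold lower number from compound 2 to compound 3 (0.19 log units; within the scatter) and also a 1.3-fold lower number from compound 1 to compound 3 (0.12 log units; within the scatter) for this change. The earlier step covered only a swap between 4-substituted aryl groups, whereas these steps show that 2-ethylphenyl, with 8 heavy atoms against 7 in 4-methylphenyl, also stays inside the scatter. No supporting measurement is available to interpret these steps.

From the compounds shown here alone, whether 4-ethylphenyl or 2-methylphenyl would separate the effect of chain from that of ring position remains open. Also open, going by these compounds, is whether an amine or a carboxylic acid on this aryl ring would give a step beyond the scatter.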